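The source may report more compounds than this note shows. Statements on the series, on what has been measured and on what is new or still open speak of the compounds shown alone.

Of the compounds shown here, three built on one shared core have been tested in an assay on membranes from HeLa cells for displacement of a labelled ligand from adenosine receptor A3 (Homo sapiens), read by scintillation counting, with a stated time of 180 min, tested at 1 uM; on this read-out higher numbers stand for more inhibition at the one concentration tested (going by the name of the read-out) and lower numbers for less inhibition. Compound 1 `CC1=C(C(=O)OC(C)(C)C)C(c2ccsc2)NC(=O)N1` gives 1%, compound 2 `CCCC(=O)C1=C(C)NC(=O)NC1c1ccoc1` gives 2%, and compound 3 `CC1=C(C(=O)C2CC2)C(c2ccsc2)NC(=O)N1` gives 1%. Compound 3 thus stands level with compound 1 at the digits shown, the two together making up the lowest pair of the three numbers, and compound 2 also falls within the usual scatter of both, so that nothing separates the three results in a meaningful way.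

For the measured compounds named here, compound 4 `CCCC(=O)C1=C(C)NC(=O)NC1c1ccsc1` is the next compound in line. propyl in place of cyclopropyl on a carbonyl carbon Only one measured step concerns a swap on that same carbonyl carbon: no change at the digits printed from compound 1 to compound 3 (within the scatter), where cyclopropyl took the place of tert-butoxy and nothing moved beyond the scatter. Compound 2 already carries propyl on its carbonyl carbon, though with a different aromatic ring attached to the core, and its value of 2% is likewise low. Nothing among these results points to a step beyond the scatter in either direction.

Compound 4 is therefore expected to give 2% in this assay, with a range from -8% to 12%. The step this estimate means, a number 1 percentage points higher from compound 3 to compound 4 (within the scatter), is expected to be no change beyond the scatter.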

Compound 4, a percentage reported as inhibition, at one concentration (the size of the read-out at that concentration, not a potency): 1%
Estimate against measurement, compound 4: 1 percentage points above; low and high end bracket the measured number.
By their numbers in this assay, from the lowest: compounds 1, 3, 4 and 2 (each within the scatter of the next).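

In this assay, replacing the cyclopropyl ring with an open propyl chain on the carbonyl carbon gives no change at the digits printed from compound 3 to compound 4 (within the scatter), so at this position the ring and the chain cannot be told apart. For the compounds shown here, replacing tert-butoxy with propyl at the same place gives no change at the digits printed from compound 1 to compound 4 (within the scatter), and the first single change at a second place, thiophen-3-yl in place of furan-3-yl on a saturated ring carbon, gives a number 1 percentage points lower from compound 2 to compound 4 (within the scatter). Neither of the two places has yet shown a change beyond the scatter, and no supporting data offer any explanation for these results.

On these data alone, it remains open whether an amine, a carboxylic acid or a longer chain such as octyl on the carbonyl carbon, or a phenyl ring on the saturated ring carbon, would move the number beyond the scatter. Since each compound was read at one concentration only, these numbers also leave open how any of them would behave at higher concentrations.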